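Swapping the Hydroxyamino Group of Compound 1 for Trifluoromethyl

The compounds below may be only part of what the source reports. "The series", "measured", "known", "first", "only" and "open" are said of these compounds alone.

Of the compounds shown here, three have been measured in a functional assay on A549 cells (Homo sapiens) for antiproliferative activity, read by MTT assay, with a stated time of 72 h; a higher number here means a weaker inhibitor, a lower number a stronger inhibitor. Compound 1 (`O=C(CCCCCCc1nc(-c2cccc([N+](=O)[O-])c2)no1)NO`) gives 10800 nM. Compound 3 (`Cc1ccc(-c2noc(CCCCCCC(=O)Nc3ccccc3N)n2)cc1`) gives 9170 nM, which lies within the scatter of compound 1. Compound 2 (`O=C(CCCCCCc1nc(-c2cccs2)no1)NO`) gives 4370 nM, a lower number than compound 1 by more than the scatter. Compound 1 therefore sits at the weak end of this small set, level with compound 3.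

Compound 4 (`O=C(CCCCCCc1nc(-c2cccc([N+](=O)[O-])c2)no1)C(F)(F)F`) has not yet been measured. It keeps the core and chain of compound 1 but carries trifluoromethyl in place of hydroxyamino on a carbonyl carbon. Going by the values given here, no measured pair isolates this change, so its size cannot be read from the data and the expectation is a judgement. A moderate shift towards a higher number, and so a weaker inhibitor, seems more likely than none. The expected change is a 1.7-fold higher number from compound 1 to compound 4 (0.22 log units; within the scatter). For compound 4 the estimated value is 18000 nM, with an expected range of 6000 nM to 50000 nM.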

Compound 4, half-maximal inhibitory concentration: 9580 nM
For compound 4 the middle estimate is 1.9-fold (0.27 log units) above the measured one; the range from low to high includes it.
By their numbers in this assay, from the lowest: compound 2; then compounds 3, 4 and 1 (each within the scatter of the next).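

In this assay, trifluoromethyl in place of hydroxyamino on a carbonyl carbon gives a 1.1-fold lower number from compound 1 to compound 4 (0.05 log units; within the scatter), a step within the scatter. Going by these compounds alone, this is the first step in the set that isolates a single change, and it shows that, on the core of compound 1, hydroxyamino can be replaced at this place without a readable change in this read-out. Nothing available bears on why this exchange leaves the number level.

Going by these compounds, it remains open whether other groups on this carbonyl carbon, such as an amine or a methoxy group, would also leave the number level. On these data alone, it is equally open whether the same exchange would give so small a step on the core of compound 2, or with a longer chain.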